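The source may report more compounds than this note shows. Statements on the series, on what has been measured and on what is new or still open speak of the compounds shown alone.

Measured compounds:

compound 1, `CCNCC(=O)Nc1cc(OC)ccc1C(=O)c1ccc(OC)c2c1C=CC(C)(C)O2`: 7230 nM
compound 2, `CCNCC(=O)Nc1cc(OC)ccc1C(=O)c1ccc2c(c1)C=CC(C)(C)O2`: 6310 nM
compound 3, `COc1ccc(C(=O)c2ccc(OC)c3c2C=CC(C)(C)O3)c(NC(=O)CN(C)C)c1`: 6530 nM

The three measured compounds were tested in a functional assay on MCF7 cells (Homo sapiens) for antiproliferative activity, read by MTT assay, with a stated time of 48 h; a higher number here means a weaker inhibitor, a lower number a stronger inhibitor. In this assay compound 1 gives 7230 nM, compound 2 gives 6310 nM and compound 3 gives 6530 nM; all three numbers sit close together, and none of the gaps between them reaches beyond the usual scatter of this kind of measurement.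

Compound 1 and compound 3 share a core and differ in one place: dimethylamino in place of ethylamino on a saturated chain carbon bound to a carbonyl carbon. That change produced a 1.1-fold lower number from compound 1 to compound 3 (0.04 log units; within the scatter), so on this core the exchange of the amine left the result essentially where it was. Compound 2 carries a different core from compound 1; the difference between the two cores is not broken down here.

Compound 4, `COc1ccc(C(=O)c2ccc3c(c2)C=CC(C)(C)O3)c(NC(=O)CN(C)C)c1`, has not yet been measured. It stands to compound 2 as compound 3 stands to compound 1: dimethylamino in place of ethylamino on a saturated chain carbon bound to a carbonyl carbon. The place of the change is the same in both pairs, so this is the same change seen once already. Going by the values given here, the only guide to its size is the pair already measured, where the step from compound 1 to compound 3 was a 1.1-fold lower number from compound 1 to compound 3 (0.04 log units; within the scatter), and compound 4 is therefore expected to move from compound 2 by about a 1.1-fold lower number from compound 2 to compound 4 (0.04 log units; within the scatter). On that basis, compound 4 is estimated to give 5800 nM in this assay, with a plausible range from 3000 nM to 11000 nM, resting on the near-neutral step seen from compound 1 to compound 3, a 1.1-fold lower number from compound 1 to compound 3 (0.04 log units; within the scatter), and on the value of compound 2, 6310 nM.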

Compound 4, half-maximal inhibitory concentration: 3560 nM
Estimate against measurement, compound 4: 1.6-fold (0.21 log units) above; the range from low to high includes it.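

On the other core, in this assay, the same exchange of ethylamino for dimethylamino on a saturated chain carbon bound to a carbonyl carbon gave a 1.8-fold lower number from compound 2 to compound 4 (0.25 log units; within the scatter), so here too the step does not rise above the usual noise of such measurements. Set beside the earlier step, the two readings cannot be told apart, and the change carried from one core to the other without a detectable difference: the same change on two cores in this assay, a 1.1-fold lower number (0.04 log units; within the scatter) from compound 1 to compound 3 and a 1.8-fold lower number (0.25 log units; within the scatter) from compound 2 to compound 4, 1.6-fold (0.20 log units) apart, within the scatter of two such steps This shows only that the exchange stayed within the scatter on these two cores; it does not show that the change has a real effect of its own, that a small dependence on the core is absent, or that the same would hold on any further core in the series.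

The compounds shown leave open whether a larger departure from these two small amines, such as a ring amine like morpholine or piperidine, an unsubstituted amino group, or a longer chain between the carbonyl and the amine, would shift the number beyond the scatter. They also leave open whether the near-neutral behaviour of this exchange extends to cells other than those of this assay.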